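Melatonin type 1C series: acyl chain extension at compound 2

This account rests on a few compounds, and the source may have more. Where it says the series, first, only, none or still open, it means among the compounds named here.

Measured so far:
compound 1 `CCCC(=O)NCc1ccc(OC)c(F)c1`: 661 nM
compound 2 `COc1ccc(F)c(CCCNC(C)=O)c1`: 20.4 nM

In an assay on isolated protein for agonist activity at melatonin receptor type 1C (Xenopus laevis), read by spectrophotometry (on this read-out higher numbers stand for an effect only at larger amounts of compound and lower numbers for an effect already at smaller amounts), compound 1 gives 661 nM, while compound 2 gives 20.4 nM. Compound 2 therefore holds the lowest of the two numbers; the gap to compound 1 lies beyond the scatter, but the two structures differ in more than one place, so the two values can only be set side by side. Compound 3 `CCC(=O)NCCCc1cc(OC)ccc1F` is still to be measured in this assay. It differs from compound 2 by methyl in place of hydrogen on a saturated chain carbon bound to a carbonyl carbon. Going by the values given here, no step between measured compounds covers this change, so the size of the step is unknown. The expected step from compound 2 to compound 3 is a 1.5-fold lower number from compound 2 to compound 3 (0.16 log units; within the scatter), with a modest gain or no change beyond the scatter. For compound 3 the estimate in this assay is 14 nM, expected within 5 nM to 45 nM.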

Compound 3, half-maximal effective concentration: 3.72 nM
For compound 3 the middle estimate is 3.8-fold (0.58 log units) above the measured one, and the stated range ends above it.
By their numbers in this assay, from the lowest: compound 3; then compound 2; then compound 1.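

In this assay the change from acetyl to propanoyl, with the rest of the structure held fixed, gives a 5.5-fold lower number from compound 2 to compound 3 (0.74 log units; beyond the scatter). Going by these compounds alone, this is the first one-place comparison, and it shows that a saturated chain carbon bound to a carbonyl carbon accepts methyl in place of hydrogen with a lower number, not merely without loss. No measurement shown accounts for the size of this step.

Going by these compounds, a single step gives no trend, so it remains open whether the number keeps falling with a longer acyl chain such as pentanoyl or reverses there. Branched or cyclic replacements at the same carbon, such as isobutanoyl or cyclopropanecarbonyl, and a heteroatom-bearing chain such as methoxyacetyl, also remain open.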